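Swapping dipropylamino for (3-chlorophenyl)amino when only limits exist

The source may report more compounds than this note shows. Statements on the series, on what has been measured and on what is new or still open speak of the compounds shown alone.

In a functional assay on HeLa cells (Homo sapiens) for inhibition, read by sulforhodamine B assay (on this read-out lower numbers stand for stronger inhibition and higher numbers for weaker inhibition), compound 1 (`O=C1C=C(NCc2ccccc2)C(=O)c2c1nc1n2[C@H]2OC[C@@H](O)[C@H]2OC1`) gives > 8000 nM as its result, which is a limit and not a number. Compound 2 (`O=C1C=C(Nc2ccc(C(F)(F)F)cc2)C(=O)c2c1nc1n2[C@H]2OC[C@@H](O)[C@H]2OC1`) gives > 8000 nM as its result, also a limit. Compound 3 (`CCCN(CCC)C1=CC(=O)c2nc3n(c2C1=O)[C@H]1OC[C@@H](O)[C@H]1OC3`) gives > 16000 nM as its result, again a limit. Compound 3 therefore stands without a number, and so do the other two.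

Compound 4 (`O=C1C=C(Nc2cccc(Cl)c2)C(=O)c2c1nc1n2[C@H]2OC[C@@H](O)[C@H]2OC1`) carries (3-chlorophenyl)amino in place of dipropylamino on a double-bonded ring carbon. Among the compounds with values here, two measured steps bear on this change, one for the group on the amine nitrogen (a step that the two limits leave unreadable from compound 1 to compound 2) and one for the dipropylamino group (a step that the two limits leave unreadable from compound 1 to compound 3). Neither gives a size that could be carried over.

Compound 2 also has a phenyl ring on the amine nitrogen, which makes it the closest guide, and its result of > 8000 nM is a limit. No readable step and no firm direction can therefore be expected in this assay for this change. The estimated change is an at least 1.6-fold lower number from compound 3 to compound 4 (0.20 log units; that floor lies within the scatter) and this expectation is loose. For compound 4 the estimated value is 10000 nM with an expected range from 3000 nM to 30000 nM and the result may well be only a limit again.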

Compound 4, half-maximal inhibitory concentration: 6040 nM
The estimate for compound 4 lay 1.7-fold (0.22 log units) above the measured number; low and high end bracket the measured number.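

A measured number now appears in this assay for a group on this double-bonded ring carbon, and placing (3-chlorophenyl)amino there in place of dipropylamino gives an at least 2.6-fold lower number from compound 3 to compound 4 (0.42 log units; beyond the scatter). The change on the amine nitrogen is much less clear, since 3-chlorophenyl in place of 4-(trifluoromethyl)phenyl gives an at least 1.3-fold lower number from compound 2 to compound 4 (0.12 log units; that floor lies within the scatter), while 3-chlorophenyl in place of benzyl gives an at least 1.3-fold lower number from compound 1 to compound 4 (0.12 log units; that floor lies within the scatter), and neither floor clears the usual scatter on its own. The step to the new number starts from a result for compound 3 that is a limit and not a number: the limit of > 16000 nM in this assay, at which 1 of the 4 values shown sits.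

As far as these compounds go, the true distance from compound 1 and compound 2 to the new result stays open, as each of these two has only a limit: the limit of > 8000 nM in this assay, at which 2 of the 4 values shown sit. Also open is how an unsubstituted phenyl ring on the amine nitrogen, or a phenyl ring carrying a methoxy group or a carboxylic acid, would compare with 3-chlorophenyl in this assay.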